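This account rests on a few compounds, and the source may have more. Where it says the series, first, only, none or still open, it means among the compounds named here.

Working notes on a small sulfonamide series sharing one core, followed in a functional assay on CHO-TAX 5-6 cells (Cricetulus griseus) for antiproliferative activity, read by sulforhodamine B assay, with a stated time of 48 h; on this read-out lower numbers stand for stronger inhibition and higher numbers for weaker inhibition. Compound 1 (`COc1cc(NS(=O)(=O)c2ccc(N3CCNC3=O)cc2)cc(OC)c1OC`) gives 170 nM, and compound 2 (`O=C1NCCN1c1ccc(S(=O)(=O)Nc2cccc(Br)c2)cc1`) gives 76 nM. Compound 2 therefore holds the lower of the two numbers, and its gap to compound 1 lies beyond the usual scatter of repeated measurements.

Compound 3 (`Cc1ccc(C)c(NS(=O)(=O)c2ccc(N3CCNC3=O)cc2)c1`) is still unmeasured in this assay. It carries 2,5-dimethylphenyl in place of 3-bromophenyl on a sulfonamide nitrogen. Going by the values given here, the series offers no measured step for a swap of this kind, so the expectation is loose and rests on the two available numbers. With compound 1 at 170 nM and compound 2 at 76 nM, a result in the same general region is expected for the new aryl group. The expected change is a 1.6-fold higher number from compound 2 to compound 3 (0.20 log units; within the scatter), a small rise in the number that would stay within the scatter. The estimated value for compound 3 is 120 nM, with an expected range from 40 nM to 400 nM.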

Compound 3, half-maximal inhibitory concentration: 54 nM
Estimate against measurement, compound 3: 2.2-fold (0.35 log units) above, and the stated range covers the measured number.
By their numbers in this assay, from the lowest: compounds 3 and 2 (each within the scatter of the next); then compound 1.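

In this assay the series now has its first measured step on a sulfonamide nitrogen, a 1.4-fold lower number from compound 2 to compound 3 (0.15 log units; within the scatter), for 2,5-dimethylphenyl in place of 3-bromophenyl. This step lies within the scatter, so compounds 2 and 3 cannot be separated, and the place tolerates the loss of bromine and the arrival of two methyl groups on the aromatic ring without a readable change in the number; this holds for this one pair only and does not set a trend across aryl groups. The data on hand offer no measurement that could account for the closeness of these two values.

A single swap changes the bromine and both methyl groups together, so the separate contribution of each remains unresolved, and an unsubstituted phenyl would be needed to divide it. Also open, from the compounds shown here alone, is whether this place accepts anything other than a substituted phenyl ring, such as a cyclohexyl group or a phenyl ring carrying an amine or a carboxylic acid, while the number stays in the same region.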